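This account rests on a few compounds, and the source may have more. Where it says the series, first, only, none or still open, it means among the compounds named here.

Measured in a functional assay (Left cardiac atrium, Cavia porcellus), with a stated time of 30 min; a higher number here means that more compound is needed for the effect, a lower number that less compound is needed:
- compound 1 (`CC1=CSC(O)(c2ccccc2)c2noc(=O)n21`): (230 nM)
- compound 2 (`CC1=CSC(OCC2CCCCC2)(c2ccccc2)c2noc(=O)n21`): (870 nM)

Compound 1 (230 nM) holds the lower of the two numbers. Compound 3 (`COc1ccccc1C1(O)SC=C(C)n2c1noc2=O`) carries methoxy in place of hydrogen on an aromatic carbon. Among the measured compounds shown here, the only measured step (a 3.8-fold higher number from compound 1 to compound 2 (0.58 log units; beyond the scatter)) is modest and lies at an oxygen on a saturated carbon, so it bears only loosely on this change. For the measured compounds named here, no measured step touches the aromatic carbon. In this assay a small move toward a higher number is expected, though one within the scatter remains possible. The expected step is (a 1.4-fold higher number from compound 1 to compound 3 (0.14 log units; within the scatter)). For compound 3 the estimated value is 320 nM with an expected range from 100 nM to 1000 nM in this series.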

Compound 3, half-maximal effective concentration: 930 nM
Beside the measured number, compound 3's estimate is 2.9-fold (0.46 log units) below it; measured number inside the range.
By their numbers in this assay, from the lowest: compound 1; then compounds 2 and 3 (each within the scatter of the next).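

In this assay, methoxy in place of hydrogen on an aromatic carbon, ortho to a large group, gives a 4.0-fold higher number from compound 1 to compound 3 (0.61 log units; beyond the scatter). Among the compounds shown here, this is the first sign that the six-membered aromatic ring responds to substitution, and the change moves the number beyond the scatter with the hydroxyl of compound 1 kept in place. Nothing measured here accounts for the shift.

Going by these compounds, whether fluorine or ethoxy on this same carbon would move the number as methoxy does stays open. So does the effect of methoxy on another carbon of that ring.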